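Adding one carbon to a short side chain

The source may report more compounds than this note shows. Statements on the series, on what has been measured and on what is new or still open speak of the compounds shown alone.

Measured so far in a physicochemical assay for lipophilicity; a lower number here means a more polar compound, a higher number a more lipophilic compound:
- Compound 1 `CCCCCCCc1nc2ccccc2[nH]1` gives 4.43
- Compound 2 `c1ccc2cc(Cc3nc4ccccc4[nH]3)ccc2c1` gives 4.79
- Compound 3 `CCCc1nc2cc(C)c(C)cc2[nH]1` gives 3.4

Compound 3 at 3.4 is the lowest of these three numbers. Compound 1 at 4.43 lies nearest to it and compound 2 at 4.79 lies furthest, and both gaps are beyond the scatter of the method.

Compound 4 `CCCCc1nc2cc(C)c(C)cc2[nH]1` differs from compound 3 by methyl in place of hydrogen on a saturated chain carbon, three bonds along the chain from an aromatic carbon on a saturated chain carbon, three bonds along the chain from an aromatic carbon, which reads as propyl to butyl. Among the compounds with values here, no measured pair shows this change alone, so there is no direct precedent for its size. Within the data shown here, the one hint is that compound 1 with its longer chain reads 4.43 against compound 3 at 3.4 although those two also differ elsewhere. A modest rise in this assay is therefore expected, a little beyond the scatter. The estimate is a number 0.50 log units higher from compound 3 to compound 4 (beyond the scatter) as an expected rise. For compound 4 the estimated value is 3.9 with 3.6 to 4.2 as the expected range.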

Compound 4, partition coefficient: 3.9
Compound 4: the middle estimate sits on the measured number at the digits printed; measured number inside the range.
By their numbers in this assay, from the lowest: compound 3; then compound 4; then compound 1; then compound 2.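

In this assay, the change from propyl to butyl now has a direct reading on an otherwise unchanged core. Within the data shown here, the step is a number 0.50 log units higher from compound 3 to compound 4 (beyond the scatter) for one methyl in place of hydrogen on a saturated chain carbon, three bonds along the chain from an aromatic carbon, so a single added carbon at this place is enough to move the number past the usual scatter, something the earlier compounds, which differ in more than one place, could not show. No measurement at hand explains why the step has this size.

A single step cannot show whether a longer chain than butyl on this core would keep adding a similar amount. It also leaves open how this assay would read with an amine or a carboxylic acid in place of that methyl.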